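The source may hold more compounds than are shown below. What is called first, only, known or untested is meant among the compounds shown, and "the series" means these compounds.

Measured compounds:
- compound 1, `CCCc1ccc(C(=O)Nc2cccc(NC(=O)COc3ccc4c(=O)ccoc4c3)c2)cc1`: 14 nM
- compound 2, `Cc1nc(C(=O)Nc2cccc(NC(=O)COc3ccc4c(=O)ccoc4c3)c2)cs1`: 33 nM
- compound 3, `Cn1ccc(S(=O)(=O)Nc2cccc(NC(=O)COc3ccc4c(=O)ccoc4c3)c2)n1`: 1350 nM

In an assay on isolated protein for inhibition of Rho-associated protein kinase 2 (Homo sapiens), read by scintillation counting, radiometric assay and 33P incorporation, with a stated time of 40 min, in the presence of a further agent that is not named here (a lower number here means a stronger inhibitor, a higher number a weaker inhibitor), compound 3 gives the highest number of the three, that is, it is the weakest inhibitor here: the step is a 96-fold higher number from compound 1 to compound 3 (1.98 log units; beyond the scatter) and a 41-fold higher number from compound 2 to compound 3 (1.61 log units; beyond the scatter). Compound 4, `CN(C)c1ccc(S(=O)(=O)Nc2cccc(NC(=O)COc3ccc4c(=O)ccoc4c3)c2)cc1`, keeps the shared core and the sulfonyl group of compound 3 and changes only the ring on it: 4-(dimethylamino)phenyl in place of 1-methyl-1H-pyrazol-3-yl on a sulfonyl sulfur.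

Within the data shown here, no measured step changes a ring on a sulfonyl sulfur alone. The two steps ending at compound 3 swap both the carbonyl for a sulfonyl and the ring, so they show only how far compound 3 sits from the amides. The step of a 2.4-fold higher number from compound 1 to compound 2 (0.37 log units; beyond the scatter) shows that, on a carbonyl carbon, a six-membered carbon ring gave a modestly lower number than a five-membered ring with two hetero atoms. Taken over to the sulfonyl, a modest fall in the number is expected for compound 4, with wide uncertainty. Compound 4 is therefore estimated at 500 nM, within a range of 150 nM to 2500 nM. This estimate amounts to an expected step of a 2.7-fold lower number from compound 3 to compound 4 (0.43 log units; beyond the scatter).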

Compound 4, half-maximal inhibitory concentration: 263 nM
Beside the measured number, compound 4's estimate is 1.9-fold (0.28 log units) above it; low and high end bracket the measured number.
By their numbers in this assay, from the lowest: compound 1; then compound 2; then compound 4; then compound 3.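

In this assay, among these compounds, the step of a 5.1-fold lower number from compound 3 to compound 4 (0.71 log units; beyond the scatter) is the first to change only the ring on a sulfonyl sulfur, so it shows that this ring alone can move the number beyond the scatter while the sulfonyl stays in place. The direction matches the one seen on a carbonyl carbon, where a 2.4-fold higher number from compound 1 to compound 2 (0.37 log units; beyond the scatter) also gave the six-membered carbon ring the lower number, although the rings in the two pairs are not the same. Nothing measured here explains why the ring matters.

As far as these compounds go, it remains open how much of the fall belongs to the six-membered carbon ring and how much to the dimethylamino group, which a plain phenyl on the sulfonyl sulfur would separate. Among the compounds shown here, the cost of the sulfonyl itself also stays unknown, since no pair here carries the same ring on both a carbonyl carbon and a sulfonyl sulfur.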